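A few compounds are considered here, and "the series" means these few. Any claim that something is new, unique, unknown or untested is made for them only; others in the source may bear on it.

Working notes on the series.

Compound 1 `Nc1cccc(-c2cn3nc(Cc4ccc(Cl)cc4)sc3n2)c1` and compound 2 `COc1ccc(Cc2nn3cc(-c4cccc(N)c4)nc3s2)cc1` share a core; compound 3 `C=C(Br)C(=O)Nc1cccc(-c2cn3c(-c4ccc(Cl)cc4)csc3n2)c1` and compound 4 `C=C(Br)C(=O)Nc1cccc(-c2cn3c(-c4ccc(OC)cc4)csc3n2)c1` share a second core. The difference between the two cores is not broken down here. In a functional assay on HeLa cells (Homo sapiens) for inhibition, read by cell counting, with a stated time of 4 days (a higher number here means a weaker inhibitor, a lower number a stronger inhibitor), compound 1 gives 25000 nM, and compound 2 gives 191000 nM. The step between them, a 7.6-fold higher number from compound 1 to compound 2 (0.88 log units; beyond the scatter), belongs to a single change, (methoxy in place of chloro on an aromatic carbon).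

Compound 3 gives 3000 nM in this assay, the lowest number of the three measured compounds; its nearest neighbour is compound 1, and compound 2 lies furthest away.

Compound 4 carries the same change as compound 2 does against compound 1: methoxy in place of chloro on an aromatic carbon. The place, on an aromatic carbon of a six-membered aromatic ring of carbon only, para to a large group, reads the same for both pairs, so the change is the same, although the surrounding cores are not identical and the shift in the second core cannot be checked against any measured pair.

Going by the values given here, for compound 4 a step of about the size seen once already is expected in this assay, a 6.7-fold higher number from compound 3 to compound 4 (0.82 log units; beyond the scatter), resting on the one measured step of a 7.6-fold higher number from compound 1 to compound 2 (0.88 log units; beyond the scatter). Compound 4 is therefore estimated at 20000 nM, with the number expected to fall between 6000 nM and 70000 nM.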

Compound 4, half-maximal inhibitory concentration: 860 nM
Compound 4: middle estimate off by 23-fold (1.37 log units), on the high side; measured number outside the range, below it.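

In this assay, methoxy in place of chloro on an aromatic carbon gives a 3.5-fold lower number from compound 3 to compound 4 (0.54 log units; beyond the scatter), so on the core of compound 3 the methoxy compound has the lower number, whereas on the core of compound 1 it has the higher one. The step therefore does not carry from one core to the other in this series, either in size or in direction, and the measured step on one core gives no safe estimate for the other: the same change on two cores in this assay, a 7.6-fold higher number (0.88 log units; beyond the scatter) from compound 1 to compound 2 and a 3.5-fold lower number (0.54 log units; beyond the scatter) from compound 3 to compound 4, 27-fold (1.43 log units) apart, beyond the scatter of two such steps

This does not show which structural difference between the two pairs goes with the reversal, since compounds 1 and 2 differ from compounds 3 and 4 in more than one place, nor does one pair on each core establish a general rule for either core.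

As far as these compounds go, whether fluoro, hydroxyl or dimethylamino at the same place on the aromatic ring would follow methoxy or chloro on each core remains open. Also open, from the compounds shown here alone, is whether the reversal would persist if a plain acrylamide replaced the bromine-bearing amide of compounds 3 and 4, which would help separate that group's part from the core's.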